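The source may report more compounds than this note shows. Statements on the series, on what has been measured and on what is new or still open speak of the compounds shown alone.

In a functional assay on K562 cells (Homo sapiens) for cytotoxicity, read by spectrophotometry (on this read-out higher numbers stand for weaker inhibition and lower numbers for stronger inhibition), compound 1 `CC(=O)O[C@H]1[C@H](O[C@H]2CC[C@](C)(OC(C)=O)[C@@H](CC/C(C)=C/C[C@H](/C=C(\C)[C@H](C[C@@H]3C(C)=CCC(=O)C3(C)C)OC(C)=O)OC(C)=O)C2(C)C)O[C@H](CO)[C@H](O)[C@@H]1O` gives 12500 nM. Compound 2 `CC(=O)O[C@@H](C[C@@H]1C(C)=CCC(=O)C1(C)C)/C(C)=C/[C@H](O)C/C=C(\C)CC[C@H]1C(C)(C)[C@@H](O[C@@H]2O[C@H](CO)[C@H](O)[C@H](O)[C@H]2O)CC[C@]1(C)OC(C)=O` reaches only a limit of this assay, > 100000 nM. Compound 3 `CC(=O)O[C@@]1(C)CC[C@H](O[C@@H]2O[C@H](CO)[C@H](O)[C@H](O)[C@H]2O)C(C)(C)[C@@H]1CC/C(C)=C/C[C@@H](O)/C=C(\C)[C@@H](O)C[C@@H]1C(C)=CCC(=O)C1(C)C` likewise returns only a limit, > 100000 nM, and so it stands at the limit of > 100000 nM in this assay, at which 2 of the 3 values shown sit. The step that the two limits leave unreadable from compound 2 to compound 3 therefore cannot be sized, as both of its ends are limits. Compound 4 `CC(=O)O[C@@]1(C)CC[C@H](O)C(C)(C)[C@@H]1CC/C(C)=C/C[C@@H](O)/C=C(\C)[C@@H](O)C[C@@H]1C(C)=CCC(=O)C1(C)C` differs from compound 3 by hydrogen in place of 3,4,5-trihydroxy-6-(hydroxymethyl)oxan-2-yl on an oxygen on a saturated carbon. No measured step among these compounds covers this change, so the numbers shown give no size or direction for it. The value of compound 4 is expected near 60000 nM, within a range from 15000 nM to 200000 nM. The expected step of an at least 1.6-fold lower number from compound 3 to compound 4 (0.22 log units; that floor lies within the scatter) is accordingly left open and may again end at a limit.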

Compound 4, half-maximal inhibitory concentration: 14800 nM
Beside the measured number, compound 4's estimate is 4.1-fold (0.61 log units) above it; measured number below the stated range.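

In this assay, among the compounds shown here, this is the first readable step at the oxygen on a saturated carbon: hydrogen in place of 3,4,5-trihydroxy-6-(hydroxymethyl)oxan-2-yl gives an at least 6.7-fold lower number from compound 3 to compound 4 (0.82 log units; beyond the scatter). The change therefore has a direction, and the compound without this group gives a measured number in place of a limit. The step's size is only a floor, as compound 3 returns a limit: the limit of > 100000 nM in this assay, at which 2 of the 4 values shown sit.

As far as these compounds go, whether a methyl ether, an acetyl or an amine at this place would give a similar number stays open. So does the effect of the same change with the acetyl groups elsewhere on the compound altered.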